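This account rests on a few compounds, and the source may have more. Where it says the series, first, only, none or still open, it means among the compounds named here.

Measured so far in this series:

- compound 1, `COc1ccc(-c2cc(/C=C/C(=O)c3ccc(N)cc3)[nH]n2)cc1`: 88%
- compound 2, `COc1cc(-c2cc(/C=C/C(=O)c3ccc(N)cc3)[nH]n2)cc(OC)c1OC`: 91%

Both numbers come from a functional assay on RXF 393 cells (Homo sapiens) for cytotoxicity, read by sulforhodamine B assay, with a stated time of 48 h, tested at 0.1 uM; on this read-out lower numbers stand for a stronger effect and higher numbers for a weaker effect at the one concentration tested. Compound 1 gives 88% in this assay, and compound 2 gives 91%. Compound 2 has the higher of the two numbers, but the nearest neighbour, compound 1, lies only slightly lower, and that gap sits within the usual scatter of repeated measurements. The two values are therefore read as indistinguishable; neither compound can be called the weaker or the stronger of the pair on this evidence.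

Compound 3, `COc1ccc(-c2cc(/C=C/C(=O)c3ccc(N)cc3)[nH]n2)cc1OC`, has not been measured in this assay. Its structure differs from compound 2 in one place:

hydrogen in place of methoxy on an aromatic carbon

Within the data shown here, no measured step of this kind exists, so the expectation rests on the two values alone. Since compound 1 and compound 2 differ by a larger structural change and yet stay within the scatter of each other, the step of a number 2 percentage points lower from compound 2 to compound 3 (within the scatter) is expected to be small, in no particular direction, and not beyond the scatter. Compound 3 is expected to give about 89% in this assay, with a plausible range from 80% to 97%.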

Compound 3, a percentage reported as activity, at one concentration (the size of the read-out at that concentration, not a potency): 92%
The estimate for compound 3 lay 3 percentage points below the measured number; low and high end bracket the measured number.
By their numbers in this assay, from the lowest: compounds 1, 2 and 3 (each within the scatter of the next).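

In this assay, the series now has its first readable single changes: hydrogen in place of methoxy on the aromatic carbon that is ortho to a methoxy group, meta to a large group and meta to a methoxy group is a number 1 percentage points higher from compound 2 to compound 3 (within the scatter), and methoxy in place of hydrogen on an aromatic carbon is a number 4 percentage points higher from compound 1 to compound 3 (within the scatter). Neither taking away nor adding this one methoxy group on the same six-membered aromatic ring separates the compounds beyond the scatter, so at this single concentration, the exchange of hydrogen and methoxy on this ring has no readable effect in these two pairs. No measurement here offers a reason for this result.

These compounds leave open whether a group other than methoxy on this ring, such as an amine, a carboxylic acid or a longer chain, would move the number beyond the scatter. They also leave open whether the same steps would stay this small at another concentration, and whether changing the amine on the other aromatic ring would matter more.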